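Aryl variation on the shared core: notes toward compound 4

The compounds below may be only part of what the source reports. "The series", "measured", "known", "first", "only" and "open" are said of these compounds alone.

Three compounds share one core and differ only in the aryl group on an aromatic carbon. Compound 1 `CCOC(=O)c1cnn(-c2nc(-c3ccc(OC)cc3)c(C#N)c(=O)n2C)c1N` gives 79 ug/mL in a functional assay, with a stated time of 150 min; on this read-out lower numbers stand for stronger inhibition and higher numbers for weaker inhibition. Compound 2 `CCOC(=O)c1cnn(-c2nc(-c3ccccc3F)c(C#N)c(=O)n2C)c1N` gives 87 ug/mL in this assay, and compound 3 `CCOC(=O)c1cnn(-c2nc(-c3ccccc3O)c(C#N)c(=O)n2C)c1N` gives 64 ug/mL in this assay. On the numbers shown compound 3 stands at the low end of the three, but the gaps are a 1.2-fold lower number from compound 1 to compound 3 (0.09 log units; within the scatter) and a 1.4-fold lower number from compound 2 to compound 3 (0.13 log units; within the scatter), both within the scatter, so no real separation among the three can be read from these values. The step of a 1.1-fold higher number from compound 1 to compound 2 (0.04 log units; within the scatter) is likewise within the scatter.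

Compound 4 `CCOC(=O)c1cnn(-c2nc(-c3ccc(N(C)C)cc3)c(C#N)c(=O)n2C)c1N` is not yet measured. It differs from compound 3 by 4-(dimethylamino)phenyl in place of 2-hydroxyphenyl on an aromatic carbon. For the measured compounds named here, the steps that bear on it are the three aryl exchanges already measured; all of them stay within the scatter, and none of them introduces the group that enters here, so no measured step points in a direction. The expected step is accordingly none beyond the scatter, a 1.1-fold higher number from compound 3 to compound 4 (0.05 log units; within the scatter). Compound 4 is estimated at 72 ug/mL in this assay, with an expected range from 40 ug/mL to 130 ug/mL. Going by the values given here, the entering group has no measured precedent, and the range is set wide.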

Compound 4, half-maximal inhibitory concentration: 115 ug/mL
Estimate against measurement, compound 4: 1.6-fold (0.20 log units) below, and the stated range covers the measured number.
By their numbers in this assay, from the lowest: compounds 3, 1, 2 and 4 (each within the scatter of the next).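

In this assay, 4-(dimethylamino)phenyl on this aromatic carbon stays within the scatter of all three earlier aryl groups: a 1.8-fold higher number from compound 3 to compound 4 (0.25 log units; within the scatter), a 1.3-fold higher number from compound 2 to compound 4 (0.12 log units; within the scatter) and a 1.5-fold higher number from compound 1 to compound 4 (0.16 log units; within the scatter). For the compounds shown here, the first of these steps also exchanges the group with a hydrogen-bond donor for one without, and the last is the single exchange of dimethylamino for methoxy on a phenyl group, so neither change separates the compounds on this read-out. With hydroxy, fluoro, methoxy and dimethylamino now covered, no aryl exchange among these four compounds moves the number beyond the scatter, and nothing on hand offers a reason for any of these steps.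

The compounds shown leave open whether a carboxylic acid or a primary amine on the phenyl group, or a cyclohexyl group in place of the phenyl group, would produce a step beyond the scatter. Going by these compounds, it also remains open whether this position is less sensitive than the rest of the shared core, since the ethyl ester is constant throughout and an amide or a carboxylic acid in its place could behave differently.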